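This account rests on a few compounds, and the source may have more. Where it says the series, first, only, none or still open, it means among the compounds named here.

The measured compounds:
compound 1, `Fc1ccc(C2=NN(c3ccccc3)C(c3cn(-c4ccccc4)nc3-c3ccc(Cl)c(Cl)c3)C2)cc1`, with 60.2%
compound 2, `CCC(=O)N1N=C(c2ccc(F)cc2)CC1c1cn(-c2ccccc2)nc1-c1ccc(Cl)c(Cl)c1`, with 75.6%
compound 3, `O=[N+]([O-])c1ccc(N2N=C(c3ccc(F)cc3)CC2c2cn(-c3ccccc3)nc2-c2ccc(Cl)c(Cl)c2)cc1`, with 65.6%

In a functional assay on the whole organism (strain Wistar) for inhibition, with Rattus norvegicus as the target, read by paw edema, with stated times of 30 min and 120 min, at a dose of 50 mg/kg by the oral route (on this read-out lower numbers stand for less inhibition and higher numbers for more inhibition at the one dose given (going by the name of the read-out)), compound 1 gives 60.2%, the lowest of the three numbers. Its nearest neighbour is compound 3, reached by a number 5.4 percentage points higher from compound 1 to compound 3 (within the scatter), a step within the scatter; the furthest is compound 2, reached by a number 15.4 percentage points higher from compound 1 to compound 2 (beyond the scatter), a step beyond the scatter. The remaining pair, a number 10 percentage points lower from compound 2 to compound 3 (within the scatter), also stays within the scatter.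

Compound 4, `Cc1ccc(C2=NN(c3ccccc3)C(c3cn(-c4ccccc4)nc3-c3ccc(Cl)c(Cl)c3)C2)cc1`, differs from compound 1 in one place: methyl in place of fluoro on an aromatic carbon. Going by the values given here, all three measured steps concern the group on the ring nitrogen of the shared core; none of them touches the ring that carries the fluoro, so no measured step bears directly on this change. With nothing pointing in either direction, compound 4 is expected to sit close to compound 1, the expected step being a number 0.2 percentage points lower from compound 1 to compound 4 (within the scatter), not beyond the scatter. The estimate for compound 4 in this assay is 60%, expected to lie between 48% and 72%.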

Compound 4, a percentage reported as inhibition, in the whole organism at one dose (the size of the read-out at that dose, not a potency): 62.5%
Beside the measured number, compound 4's estimate is 2.5 percentage points below it; low and high end bracket the measured number.
By their numbers in this assay, from the lowest: compounds 1, 4, 3 and 2 (each within the scatter of the next, the first and the last beyond it).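

In this assay, going by these compounds alone, the change from 4-fluorophenyl to 4-methylphenyl gives a number 2.3 percentage points higher from compound 1 to compound 4 (within the scatter) and is the first measured change at this place, on an aromatic carbon para to a large group; the earlier steps all concerned the group on the ring nitrogen. With phenyl on that nitrogen, fluoro and methyl cannot be told apart on this read-out at the one dose given, so this position accepts the exchange of one single heavy atom for another without a change beyond the scatter. Nothing measured here speaks to why the two groups read alike.

As far as these compounds go, whether a methoxy group, an amine or a carboxylic acid at this place would move the number stays open. So does whether the same exchange would read alike with propanoyl or 4-nitrophenyl on the ring nitrogen.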